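Methoxy for Methyl on a Fused Core

The compounds below may be only part of what the source reports. "The series", "measured", "known", "first", "only" and "open" are said of these compounds alone.

Of the compounds shown here, three sharing one core have been measured in a physicochemical assay for lipophilicity, at pH 7.4; on this read-out higher numbers stand for higher lipophilicity and lower numbers for lower lipophilicity. Compound 1 `Cc1ccc2nc(NC(C)C)nc(NCc3ccco3)c2c1` gives 3.63. Compound 3 `COc1ccc2nc(NC(C)C)nc(NCc3ccco3)c2c1` gives 3.58 in this assay; the change from compound 1 to compound 3 is methoxy in place of methyl on an aromatic carbon, and the step is a number 0.05 log units lower from compound 1 to compound 3 (within the scatter). Compound 2 `Cc1cccc2nc(NC(C)C)nc(NCc3ccco3)c12` gives 3.55 in this assay; the difference between the cores of compound 1 and compound 2 is not broken down here.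

Compound 4 `COc1cccc2nc(NC(C)C)nc(NCc3ccco3)c12` has not yet been measured in this assay. Its difference from compound 2 is methoxy in place of methyl on an aromatic carbon. Among the compounds with values here, this is the same kind of change as the one from compound 1 to compound 3, but the place differs: in compound 3 the group sits meta to a fused ring and para to a fused ring, while in compound 4 it sits ortho to a fused ring and meta to a fused ring. Because the earlier step was a number 0.05 log units lower from compound 1 to compound 3 (within the scatter), a similarly small step is expected, a number 0.05 log units lower from compound 2 to compound 4 (within the scatter). Compound 4 is therefore estimated at 3.5, with a likely range from 3.2 to 3.8.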

Compound 4, distribution coefficient: 3.35
Compound 4: middle estimate off by 0.15 log units, on the high side, and the stated range covers the measured number.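

In this assay, methoxy in place of methyl on an aromatic carbon gives a step of a number 0.20 log units lower from compound 2 to compound 4 (within the scatter), and the same change on the other core gave a number 0.05 log units lower from compound 1 to compound 3 (within the scatter). On both cores, then, the change stays within the scatter, but this does not show that the two cores respond alike or differently, since each core offers a single pair and the group sits at a different place on each. No measurement is available that bears on why either step reads as it does.

The compounds shown carry only methyl and methoxy at these places, so it remains open how an amine, a carboxylic acid or a longer chain such as ethoxy would read in this assay on either core. On these data alone, it also remains open whether the change would stay within the scatter at any other aromatic carbon of the shared core.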